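From methylamino to methoxy: the step to compound 4

The source may hold more compounds than are shown below. What is called first, only, known or untested is meant among the compounds shown, and "the series" means these compounds.

In an ADME assay on microsomes from liver (Rattus norvegicus) for metabolic stability (on this read-out lower numbers stand for slow clearance and higher numbers for fast clearance), compound 1 (`CNc1nc(NC2(C#N)CCCC(C)C2)nc(-n2cncn2)n1`) gives 96 mL/min/kg while compound 2 (`CNc1nc(NC)nc(NC2(C#N)CCCCC2)n1`) gives 210 mL/min/kg and compound 3 (`CNc1nc(NC2(C#N)CCCCCC2)nc(-n2cncn2)n1`) gives 276 mL/min/kg on the same scale. Compound 2 cannot be told apart from compound 3 within the usual scatter, whereas compound 1 stands lower by more than that scatter.

Compound 4 (`CNc1nc(NC2(C#N)CCCCC2)nc(OC)n1`) has yet to be measured. Its difference from compound 2 lies in one place (methoxy in place of methylamino on an aromatic carbon) on an aromatic carbon between two ring nitrogen atoms, where methoxy stands in place of methylamino. Among the measured compounds shown here, no measured pair differs in one place only, so this swap has no direct precedent here. Compound 2 and compound 3 differ in more than one place and still lie within the scatter of each other, with compound 3 at 276 mL/min/kg in this comparison. Compound 1 goes against this, at 96 mL/min/kg on the low side. In this assay the expectation is therefore a step no larger than the scatter, with no firm direction. The expected change is small (a 1.1-fold lower number from compound 2 to compound 4 (0.04 log units; within the scatter)) and stays inside the scatter. For compound 4 the estimated clearance is 190 mL/min/kg (expected range 95 mL/min/kg to 360 mL/min/kg).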

Compound 4, clearance: 196 mL/min/kg
Compound 4: middle estimate off by 1.0-fold (0.01 log units), on the low side; the measured number falls inside the stated range.
By their numbers in this assay, from the lowest: compound 1; then compounds 4, 2 and 3 (each within the scatter of the next).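

In this assay, among the compounds shown here, the pair of compound 2 and compound 4 is the first in the set to differ in one place only, and it gives this position a direct reading: a 1.1-fold lower number from compound 2 to compound 4 (0.03 log units; within the scatter) for methoxy in place of methylamino on an aromatic carbon. The earlier compounds shown here all differed in more than one place, so they could not isolate this swap, whereas here the rest of the structure stays the same and the two numbers cannot be told apart, even though the hydrogen-bond donor count of the group goes from 1 to 0 while the heavy-atom count stays at 2. Nothing available explains why the two numbers stay so close.

The compounds shown leave open what an ethoxy group, a dimethylamino group or a longer chain would give at this same place between the two ring nitrogen atoms, since one swap cannot describe the position as a whole. They also leave open whether methoxy in place of methylamino would read the same way in a compound that carries a different group on the other side of the shared core.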